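The change from compound 2 to compound 3

This account rests on a few compounds, and the source may have more. Where it says the series, first, only, none or still open, it means among the compounds named here.

Compound 1 `Cc1ccc(SCc2ccc(C(=O)Nc3ccccc3N)cc2)cc1` gives 3740 nM in a functional assay on SMMC-7721 cells (Homo sapiens) for antiproliferative activity, read by CCK-8 assay, with a stated time of 72 h; a higher number here means a weaker inhibitor, a lower number a stronger inhibitor
Compound 2 `Nc1ccccc1NC(=O)c1ccc(CSc2ccc(F)cc2)cc1` gives 5770 nM in this assay

Within the data shown here, compound 2 stands level with compound 1, the only other compound with a number so far. Compound 3 `Cc1cc(C)cc(SCc2ccc(C(=O)Nc3ccccc3N)cc2)c1` has not yet been measured in this assay and differs from compound 2 by a single change, (3,5-dimethylphenyl in place of 4-fluorophenyl on a sulfur), which places 3,5-dimethylphenyl where 4-fluorophenyl stood on a sulfur. Among the measured compounds shown here, only one measured step bears on this change, and only in part: a 1.5-fold higher number from compound 1 to compound 2 (0.19 log units; within the scatter), which is fluoro in place of methyl on an aromatic carbon. For the measured compounds named here, it also trades fluoro against methyl, but no measured compound carries the 3,5-dimethylphenyl group, so the data do not test that group directly. With that single small step as the guide, no change beyond the scatter is expected in this assay in either direction. The estimated step is a 1.4-fold lower number from compound 2 to compound 3 (0.14 log units; within the scatter) and is expected to be no more than noise. For compound 3 the expected value is 4200 nM, with 1600 nM to 11000 nM as the estimated range.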

Compound 3, half-maximal inhibitory concentration: 2760 nM
Compound 3: middle estimate off by 1.5-fold (0.18 log units), on the high side; measured number inside the range.
By their numbers in this assay, from the lowest: compounds 3, 1 and 2 (each within the scatter of the next, the first and the last beyond it).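

In this assay, placing 3,5-dimethylphenyl on the sulfur where 4-fluorophenyl stood gives a 2.1-fold lower number from compound 2 to compound 3 (0.32 log units; beyond the scatter) and so provides the first step among these compounds that lies beyond the scatter, though only modestly. Set against the 4-methylphenyl group of compound 1, the same change gives a 1.4-fold lower number from compound 1 to compound 3 (0.13 log units; within the scatter) and stays within the scatter, so at this position the ring with two methyl groups cannot be told apart from the ring with one, and only the 4-fluorophenyl comparison separates. No measurement at hand accounts for either step.

The compounds shown leave open how this sulfur position would respond to a ring carrying an amine or a carboxylic acid, or to a saturated ring such as cyclohexyl in place of the aromatic one. They also leave the number of methyl groups unseparated from where those groups sit, since compound 1 and compound 3 differ in both at once.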